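A Second Fluorine and Its Expected Effect on Cytotoxicity

The compounds below may be only part of what the source reports. "The series", "measured", "known", "first", "only" and "open" are said of these compounds alone.

Compound 1, `CCOC(=O)/C(O)=C/C(=O)c1cn(Cc2ccc(F)c(F)c2)c2cccc(OC)c12`: 125000 nM
Compound 2, `COc1cccc2c1c(C(=O)/C=C(\O)C(=O)O)cn2Cc1ccccc1F`: 70500 nM

Of the compounds shown here, two have been measured in an ADME assay on MT4 cells (Homo sapiens) for cytotoxicity, read by MTT assay; on this read-out lower numbers stand for higher toxicity in this test and higher numbers for lower toxicity in this test. Compound 1 gives 125000 nM, and compound 2 gives 70500 nM. Compound 2 has the lowest of the two numbers, but its nearest neighbour, compound 1, stands only a little apart, and that gap lies within the scatter of this assay, so the two values cannot be told apart.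

Compound 3, `COc1cccc2c1c(C(=O)/C=C(\O)C(=O)O)cn2Cc1c(F)cccc1F`, has not yet been measured. It differs from compound 2 in one place: fluoro in place of hydrogen on an aromatic carbon. Cut one bond further out, the change reads 2-fluorobenzyl to 2,6-difluorobenzyl.

Among the compounds with values here, no pair of measured compounds shows what such a change does in this assay, so the expectation rests on the two values alone, which sit close together. The step from compound 2 to compound 3 is expected to be a 1.1-fold lower number from compound 2 to compound 3 (0.04 log units; within the scatter), that is, no step beyond the scatter in either direction. Compound 3 is therefore expected to give about 65000 nM, with a range from 22000 nM to 190000 nM in this assay.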

Compound 3, half-maximal cytotoxic concentration: 44300 nM
Estimate against measurement, compound 3: 1.5-fold (0.17 log units) above, within the range that was stated.
By their numbers in this assay, from the lowest: compounds 3, 2 and 1 (each within the scatter of the next, the first and the last beyond it).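

Within the data shown here, the change from 2-fluorobenzyl to 2,6-difluorobenzyl gives the first reading of a single difference in this assay, with a 1.6-fold lower number from compound 2 to compound 3 (0.20 log units; within the scatter) lying within the scatter of the assay. A second fluoro on this aromatic carbon, ortho to a large group, therefore moves the number by no more than repeated measurements would, and the values of compound 2 and compound 3 cannot be told apart. The earlier pair differs in more than one place and could not show this for a single fluoro, and nothing available explains why the reading stays within the scatter.

This one step leaves open whether a larger group on the same carbon, such as chloro or trifluoromethyl, would also stay within the scatter, or whether an amine there would move the number beyond it. It also leaves open how the same fluoro change would read with the ethyl ester of compound 1 in place of the carboxylic acid shared by compound 2 and compound 3.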